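Swapping a side group at the limit of the assay

The compounds below may be only part of what the source reports. "The series", "measured", "known", "first", "only" and "open" are said of these compounds alone.

Compound 1 (`C/C=C1/[C@H](O[C@@H]2O[C@H](CO)[C@@H](O)[C@H](O)[C@H]2O)OC=C(C(=O)OC)[C@H]1CC(=O)OCCc1ccc2c(c1)OCCO2`) gives > 20000 nM in a functional assay on SK-BR-3 cells (Homo sapiens) for antiproliferative activity, read by MTT assay, with a stated time of 72 h (on this read-out higher numbers stand for weaker inhibition and lower numbers for stronger inhibition), and that figure is a limit of the assay, not a number. Compound 3 (`C=CCOC(=O)C[C@@H]1C(C(=O)OC)=CO[C@@H](O[C@@H]2O[C@H](COC(C)=O)[C@@H](OC(C)=O)[C@H](OC(C)=O)[C@H]2OC(C)=O)/C1=C/C`) gives > 20000 nM in this assay and that figure is also only a limit. For the measured compounds named here, compound 2 (`C/C=C1/[C@H](O[C@@H]2O[C@H](COC(C)=O)[C@@H](OC(C)=O)[C@H](OC(C)=O)[C@H]2OC(C)=O)OC=C(C(=O)OC)[C@H]1CC(=O)OCCCCCCCCCCCCCCC`) is the only one with a true number, 3810 nM in this assay and so the only one whose strength can be read directly. On these data alone, compound 1 therefore stands at the limit of > 20000 nM in this assay, at which 2 of the 3 values shown sit, and its real potency remains unknown.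

Compound 4 (`C/C=C1/[C@H](O[C@@H]2O[C@H](CO)[C@@H](O)[C@H](O)[C@H]2O)OC=C(C(=O)OC)[C@H]1CC(=O)OCc1ccc(OC)c(OC)c1`) shares the core of compound 1 with one change (3,4-dimethoxyphenyl in place of (2,3-dihydro-1,4-benzodioxin-6-yl)methyl on a saturated chain carbon bound to an oxygen next to a carbonyl group), which puts 3,4-dimethoxyphenyl in place of (2,3-dihydro-1,4-benzodioxin-6-yl)methyl on a saturated chain carbon bound to an oxygen next to a carbonyl group. Going by the values given here, no measured pair shows what such a swap does, so no step beyond the usual scatter is expected in this assay in either direction. The estimated step is small (a step that the limit leaves unreadable from compound 1 to compound 4) and this expectation rests on compound 1 alone, with its limit of > 20000 nM as the only anchor. For compound 4 the estimated value is 25000 nM with an expected range from 12000 nM to 50000 nM and a report of only a limit is the likeliest outcome.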

Compound 4, half-maximal inhibitory concentration: > 15000 nM
Compound 4: no number, only a limit (the forecaster's own chance of this, stated with the estimate: 80%); the middle value is on the limit's open side.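

In this assay compound 4 gives > 15000 nM, which is a limit of the assay and not a number. For the compounds shown here, compound 1 also stands only at a limit, so no step between compound 1 and compound 4 can be read. On these data alone, whether 3,4-dimethoxyphenyl in place of (2,3-dihydro-1,4-benzodioxin-6-yl)methyl changes potency at all remains open, as does the real potency of both compounds.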